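Replacing an Aryl Ring with a Propylamino Chain

The source may hold more compounds than are shown below. What is called first, only, known or untested is meant among the compounds shown, and "the series" means these compounds.

Measured so far:
- compound 1, `Cc1ccc(-c2ncnc3c2ncn3C[C@@H]2C[C@H](CO)c3ccccc32)cc1`, gives 1.4 ug/mL
- compound 2, `Cn1ncc2c1[C@H](Cn1cnc3c(Cl)nc(N)nc31)C[C@@H]2CO`, gives 3.2 ug/mL

Both compounds were tested in a functional assay on MOLT-4 cells (Homo sapiens); on this read-out lower numbers stand for stronger inhibition and higher numbers for weaker inhibition. Of the two numbers, compound 1 stands lowest with 1.4 ug/mL, and compound 2 follows with 3.2 ug/mL, a gap beyond the usual scatter. Among the compounds with values here, the two share no single point of difference, so no step between them can be read.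

Compound 3, `CCCNc1ncnc2c1ncn2C[C@@H]1C[C@H](CO)c2ccccc21`, has not yet been measured. It differs from compound 1 in one place: propylamino in place of 4-methylphenyl on an aromatic carbon. The 4-methylphenyl group is replaced by a shorter propylamino chain, which brings a hydrogen-bond donor and acceptor where there was none.

Within the data shown here, no measured pair shows such a change, so the expectation rests on compound 1 alone. The expected step is a 2.5-fold higher number from compound 1 to compound 3 (0.40 log units; beyond the scatter), a shift toward a higher number, meaning somewhat weaker inhibition. Compound 3 is therefore estimated at 3.5 ug/mL in this assay, within a range from 1.2 ug/mL to 12 ug/mL.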

Compound 3, half-maximal inhibitory concentration: 24 ug/mL
For compound 3 the middle estimate is 6.9-fold (0.84 log units) below the measured one, outside the stated range (above it).
By their numbers in this assay, from the lowest: compound 1; then compound 2; then compound 3.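

Within this assay this position proves far from indifferent to what it carries: exchanging the 4-methylphenyl group for a propylamino group gives a 17-fold higher number from compound 1 to compound 3 (1.23 log units; beyond the scatter) and thus a much weaker inhibitor. As the only single-place change shown, this step gives the first direct reading of the position, and it shows that losing the six-membered aromatic ring of carbon while gaining a chain with a hydrogen-bond donor and acceptor does not preserve inhibition of these cells. Nothing available explains why the number rises so sharply.

The step changes several features together, so the ring, the group's size and the new nitrogen cannot be told apart as the source of the loss. Open questions are whether an unsubstituted phenyl or a 4-methoxyphenyl group would hold the stronger inhibition of compound 1, and whether a benzylamino group, which joins an amine to an aromatic ring, or a longer chain such as hexylamino would recover any of what the propylamino group gives up.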